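Swapping a bromophenyl for a furan on a pyrazoline

The source may hold more compounds than are shown below. What is called first, only, known or untested is meant among the compounds shown, and "the series" means these compounds.

Measured compounds:
compound 1 `CC(=O)N1N=C(c2ccccc2)CC1c1cccc(Cl)c1Cl` gives 42900 nM
compound 2 `CC(=O)N1N=C(c2ccc(Br)cc2)CC1c1cccc(Cl)c1Cl` gives 45700 nM
compound 3 `CC(=O)N1N=C(c2ccco2)CC1c1ccc(N(C)C)cc1` gives 16100 nM

These three compounds share a core and were tested in a functional assay on IMR-32 cells (Homo sapiens) for cytotoxicity, read by sulforhodamine B assay, with a stated time of 48 h; a lower number here means a stronger inhibitor, a higher number a weaker inhibitor. Compound 2 and compound 1 lie within the scatter of each other, as the step of a 1.1-fold higher number from compound 1 to compound 2 (0.03 log units; within the scatter) shows; compound 3, which carries a furan-2-yl group and a different group on the other side of the core, gives a clearly lower number in this assay. Compound 4 `CC(=O)N1N=C(c2ccco2)CC1c1cccc(Cl)c1Cl` is the unmeasured compound. It differs from compound 2 in one place: furan-2-yl in place of 4-bromophenyl on a carbon with a double bond to nitrogen. Among the measured compounds shown here, no measured pair isolates this change, since compound 3 differs from the others in two places at once. For the measured compounds named here, the only measured step, from the hydrogen of compound 1 to the bromine of compound 2, was within the scatter, so the bromine itself carries little weight. The expected step of a 1.5-fold lower number from compound 2 to compound 4 (0.18 log units; within the scatter) is therefore modest and uncertain in direction, leaning slightly downward. For compound 4 the estimated value is 30000 nM, with a range from 10000 nM to 90000 nM.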

Compound 4, half-maximal inhibitory concentration: 62200 nM
For compound 4 the middle estimate is 2.1-fold (0.32 log units) below the measured one, within the range that was stated.
By their numbers in this assay, from the lowest: compound 3; then compounds 1, 2 and 4 (each within the scatter of the next).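

In this assay, among the compounds shown here, the step of a 1.4-fold higher number from compound 2 to compound 4 (0.13 log units; within the scatter) gives the first direct reading of this position, the carbon with a double bond to nitrogen, with the rest of the molecule unchanged. The step of a 1.4-fold higher number from compound 1 to compound 4 (0.16 log units; within the scatter) agrees with it, so furan-2-yl, phenyl and 4-bromophenyl cannot be told apart here, although the furan-2-yl is a smaller five-membered aromatic ring that carries a hydrogen-bond acceptor. Compound 4 also carries the furan-2-yl of compound 3, so this group alone does not go with the lower number of compound 3, 16100 nM.

Nothing measured here offers a reason for these readings. Going by these compounds, whether an amine or a carboxylic acid at this position would give a number beyond the scatter remains open, since all three groups compared here are aromatic rings.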